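The source may hold more compounds than are shown below. What is called first, only, known or untested is meant among the compounds shown, and "the series" means these compounds.

Working notes on the series. Going by the values given here, compound 1 `CC(=O)c1ccc(Nc2ccnc(SCC(=O)c3ccc(Br)cc3)n2)cc1` and compound 2 `CCOC(=O)c1ccc(Nc2ccnc(SCC(=O)c3ccc([N+](=O)[O-])cc3)n2)cc1` share one core but differ in two places at once, so no single step between them is counted. In a functional assay on NCI-H226 cells (Homo sapiens) for inhibition, read by sulforhodamine B assay, with a stated time of 48 h, tested at 10 uM (a lower number here means less inhibition of growth, a higher number more inhibition of growth at the concentration tested), compound 1 gives 25%. In this assay compound 2 gives 16%; the two numbers lie within the scatter of each other, so neither is set apart, and compound 2 is simply the closest measured relative of the new compound. Compound 3 `CCOC(=O)c1ccc(Nc2ccnc(SCC(=O)c3ccc(C#N)cc3)n2)cc1` is made from compound 2 by one change, (cyano in place of nitro on an aromatic carbon). Among the compounds with values here, no measured pair shows this change, so its effect is unknown from the data. The step from compound 2 to compound 3 is expected to stay within the scatter, in no particular direction, which gives a number 2 percentage points higher from compound 2 to compound 3 (within the scatter). On that basis compound 3 is estimated at 18% in this assay, with a range from 5% to 35%.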

Compound 3, percent growth inhibition at one concentration: 38%
The estimate for compound 3 lay 20 percentage points below the measured number, and the stated range ends below it.
By their numbers in this assay, from the lowest: compounds 2 and 1 (each within the scatter of the next); then compound 3.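

In this assay, going by these compounds alone, the change from 4-nitrophenyl to 4-cyanophenyl gives a number 22 percentage points higher from compound 2 to compound 3 (beyond the scatter), the first step that can be read. It shows that the group on this aromatic carbon, para to a large group, can shift growth inhibition beyond the scatter, which the comparison of compound 1 and compound 2 could not show because they differ in two places at once. This rests on a single pair, so it describes cyano in place of nitro on the ethyl ester core of compound 2 and nothing wider. No measurement bearing on the reason for the step is available.

As far as these compounds go, it remains open whether an amine or a carboxylic acid at this position would give a number nearer that of compound 2 or of compound 3. From the compounds shown here alone, it is also open whether the same change would give a step of similar size with the acetyl group of compound 1 in place of the ethyl ester.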